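This account rests on a few compounds, and the source may have more. Where it says the series, first, only, none or still open, it means among the compounds named here.

Measured compounds:
Compound 1, `CNC(=O)c1cc(C(=O)N[C@H]2CC[C@H](O)CC2)n([C@@H](C)c2cccc(Cl)c2)n1`: 196 ug/mL
Compound 2, `CNC(=O)c1cc(C(=O)N[C@H]2CC[C@H](O)CC2)n([C@@H](C)c2ccc(Cl)cc2)n1`: 102 ug/mL
Compound 3, `CNC(=O)c1cc(C(=O)N[C@H]2CC[C@H](O)CC2)c([C@@H](C)c2cccc(C)c2)o1`: > 1000 ug/mL

All three were measured in a physicochemical assay for solubility, read by HPLC, in simulated intestinal fluid, with a stated time of 16 h, at pH 6.5; on this read-out higher numbers stand for higher solubility and lower numbers for lower solubility. Compound 1 gives 196 ug/mL and compound 2 gives 102 ug/mL; the step of a 1.9-fold lower number from compound 1 to compound 2 (0.28 log units; within the scatter). For compound 3 the assay reports only a limit and not a number, namely > 1000 ug/mL, so compound 3 stands at the top of what this assay can report; (the limit of > 1000 ug/mL in this assay, at which 1 of the 3 values shown sits).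

Compound 4, `CNC(=O)c1cc(C(=O)N[C@H]2CC[C@H](O)CC2)c([C@@H](C)c2cccc(OC)c2)o1`, has not yet been measured. It differs from compound 3 in one place: methoxy in place of methyl on an aromatic carbon. For the measured compounds named here, no measured step bears on this change; the single measured step, a 1.9-fold lower number from compound 1 to compound 2 (0.28 log units; within the scatter), concerns a different change on a different core and lies within the scatter. Compound 3 already sits at the assay limit, so compound 4 is expected to remain at or close to that limit, with an estimate of 1000 ug/mL and a range from 500 ug/mL to 2000 ug/mL. The expected step of a number no higher from compound 3 to compound 4 (the limit leaves the size open) is therefore none beyond the scatter, and most likely the assay will again report only a limit.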

Compound 4, solubility: 868 ug/mL
Estimate against measurement, compound 4: 1.2-fold (0.06 log units) above; the measured number falls inside the stated range.
By their numbers in this assay, from the lowest: compounds 2 and 1 (each within the scatter of the next); then compound 4. At a limit, above all of these: compound 3.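

Placed on an aromatic carbon of a six-membered aromatic ring of carbon only, meta to a large group, methoxy in place of methyl gives an at least 1.1-fold lower number from compound 3 to compound 4 (0.06 log units; that floor lies within the scatter) in this assay and compound 4 reads 868 ug/mL as a true number on this core. The floor of that step lies within the scatter, so the data show no firm loss from this change, though they do not rule out a larger one. Compound 3 reads > 1000 ug/mL which is a limit of the assay and not a number, so the real size of the step cannot be read: the limit of > 1000 ug/mL in this assay, at which 1 of the 4 values shown sits.

The compounds shown leave open how an amine or a carboxylic acid would read at this same place on the ring. They also leave open whether methoxy in place of methyl would give a similar result on the core of compound 1.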